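This account rests on a few compounds, and the source may have more. Where it says the series, first, only, none or still open, it means among the compounds named here.

Compound 1 `N=C(N)c1ccc(-c2ccc(-c3ccc(Br)cc3)o2)cc1`: 27 nM
Compound 2 `N=C(N)c1ccc(-c2ccc(-c3cccc([N+](=O)[O-])c3)o2)cc1`: 14.5 nM
Compound 3 `N=C(N)c1ccc(-c2ccc(-c3cccc(F)c3)o2)cc1`: 98 nM

Of the compounds shown here, three built on one shared core have been tested in an assay on isolated protein for inhibition of ribosyldihydronicotinamide dehydrogenase [quinone] (Homo sapiens), read by spectrophotometry, with a stated time of 1 min, in the absence of a further agent; a higher number here means a weaker inhibitor, a lower number a stronger inhibitor. Compound 1 gives 27 nM, the second highest of the three numbers. Its nearest neighbour is compound 2 with 14.5 nM, a gap that lies within the usual scatter, so these two cannot be ranked against each other. Compound 3, with 98 nM, sits further off: a 3.6-fold higher number from compound 1 to compound 3 (0.56 log units; beyond the scatter). Compound 2 and compound 3 also differ in a single group, and there a 6.8-fold higher number from compound 2 to compound 3 (0.83 log units; beyond the scatter).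

Compound 4 `CCc1ccc(-c2ccc(-c3ccc(C(=N)N)cc3)o2)cc1` has not yet been measured. It arises from compound 1 by one change: ethyl in place of bromo on an aromatic carbon The ethyl stands on a six-membered aromatic ring of carbon only, para to a large group. Within the data shown here, none of the measured steps makes this exchange; the two known steps concern 3-fluorophenyl in place of 4-bromophenyl and fluoro in place of nitro, and both are modest. They offer no direct guide to this change, so the expectation in this assay is a step that stays within the scatter. The expected step is a 1.1-fold higher number from compound 1 to compound 4 (0.05 log units; within the scatter). The estimate for compound 4 is 30 nM, with a range from 12 nM to 75 nM.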

Compound 4, half-maximal inhibitory concentration: 202 nM
Compound 4: middle estimate off by 6.7-fold (0.83 log units), on the low side; measured number above the stated range.
By their numbers in this assay, from the lowest: compounds 2 and 1 (each within the scatter of the next); then compound 3; then compound 4.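

In this assay, ethyl in place of bromo is not a neutral exchange: this one change gives a 7.5-fold higher number from compound 1 to compound 4 (0.87 log units; beyond the scatter), on an aromatic carbon para to a large group. The earlier steps shown here could not show this so cleanly, since one changed a group on a different compound pair and the other altered both the group and where it stands, whereas here the group alone differs at a single place on the core of compound 1. The position therefore responds strongly to what sits on it, even for a small change in the count of atoms, with one bromine leaving and two carbons entering, and with neither group carrying a hydrogen-bond donor, a hydrogen-bond acceptor or a net charge, and nothing measured here bears on why the number rises.

From the compounds shown here alone, whether a chloro, a methyl, a methoxy or a longer chain at this same carbon would land nearer compound 1 or nearer compound 4 remains open. An amine or a carboxylic acid here is equally uncharted, and so is whether this exchange would have the same size on a compound carrying another group elsewhere on the shared core.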